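A few compounds are considered here, and "the series" means these few. Any claim that something is new, unique, unknown or untested is made for them only; others in the source may bear on it.

Working notes on the series. Among the compounds with values here, the three compounds measured so far are compound 1 `COc1cc(OC)c(C(=O)/C=C/c2cn(-c3ccccc3)nc2-c2ccsc2)c(OC)c1`, compound 2 `O=C(/C=C/c1cn(-c2ccccc2)nc1-c1cccnc1)c1ccccn1` and compound 3 `O=C(/C=C/c1cn(-c2ccccc2)nc1-c1cccnc1)c1c[nH]c2ccccc12`. In a functional assay on HCT-116 cells (Homo sapiens) for inhibition, read by sulforhodamine B assay, with a stated time of 72 h (on this read-out higher numbers stand for weaker inhibition and lower numbers for stronger inhibition), compound 1 gives 5200 nM, compound 2 gives 2100 nM and compound 3 gives 6400 nM. Within the data shown here, compound 3 thus carries the highest number of the three; against compound 1 the gap lies within the scatter, against compound 2 it lies beyond it, as the single one-place step shows: a 3.0-fold higher number from compound 2 to compound 3 (0.48 log units; beyond the scatter).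

The next compound is compound 4 `COc1ccc(C(=O)/C=C/c2cn(-c3ccccc3)nc2-c2cccnc2)cc1OC`. Relative to compound 3 the change is 3,4-dimethoxyphenyl in place of 1H-indol-3-yl on a carbonyl carbon. Among the measured compounds shown here, only one measured step touches the same place, the exchange from compound 2 to compound 3, and it was modest. The values of compound 1 and compound 3 sit within the scatter of each other, which gives no direction for the new group. The step from compound 3 to compound 4 is therefore expected to be small in this assay, with the number more likely to fall than to rise: a 1.6-fold lower number from compound 3 to compound 4 (0.20 log units; within the scatter). Compound 4 is estimated at 4000 nM, within a range of 1500 nM to 11000 nM.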

Compound 4, half-maximal inhibitory concentration: 4300 nM
Compound 4: the middle estimate sits 1.1-fold (0.03 log units) below what was measured; low and high end bracket the measured number.
By their numbers in this assay, from the lowest: compound 2; then compounds 4, 1 and 3 (each within the scatter of the next).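

In this assay, the carbonyl carbon accepts 3,4-dimethoxyphenyl in place of 1H-indol-3-yl without a change beyond the scatter (a 1.5-fold lower number from compound 3 to compound 4 (0.17 log units; within the scatter)), even though the group that leaves carries a hydrogen-bond donor and the group that enters carries none. The second exchange at this place shows that pyridin-2-yl is set apart from both larger groups, not just from 1H-indol-3-yl (a 2.0-fold higher number from compound 2 to compound 4 (0.31 log units; beyond the scatter)), though this step is modest. Nothing available explains either step.

Still open, going by these compounds, is whether the lower number of compound 2 belongs to pyridin-2-yl specifically or would also appear with an unsubstituted phenyl, pyridin-3-yl or pyridin-4-yl on the carbonyl carbon. On these data alone, it is equally open whether a single methoxy group would behave as 3,4-dimethoxyphenyl does.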